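Solubility Expectation for a Biaryl Replacement of a Methoxy Group

This account rests on a few compounds, and the source may have more. Where it says the series, first, only, none or still open, it means among the compounds named here.

Measured so far:
compound 1, `COc1ccc(O)c(C(=O)Nc2ccc([N+](=O)[O-])cc2Cl)c1`: 2.1 ug/mL
compound 2, `O=C(Nc1ccc([N+](=O)[O-])cc1Cl)c1cnc2ccccc2c1O`: < 1 ug/mL

Two compounds have been run in a physicochemical assay for solubility; a lower number here means a less soluble compound, a higher number a more soluble compound. Compound 1, `COc1ccc(O)c(C(=O)Nc2ccc([N+](=O)[O-])cc2Cl)c1`, gives 2.1 ug/mL in this assay. Compound 2, `O=C(Nc1ccc([N+](=O)[O-])cc1Cl)c1cnc2ccccc2c1O`, gives < 1 ug/mL in this assay, which is a limit of the assay and not a number. Among the compounds with values here, compound 1 therefore holds the only numerical value shown; (the limit of < 1 ug/mL in this assay, at which 1 of the 2 values shown sits).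

Compound 3, `O=C(Nc1ccc([N+](=O)[O-])cc1Cl)c1cc(-c2ccc(F)cc2F)ccc1O`, has not yet been measured in this assay. It differs from compound 1 in one place: 2,4-difluorophenyl in place of methoxy on an aromatic carbon. Within the data shown here, no step between measured compounds is available to calibrate this change. With so little to go on, compound 3 is expected to show a downward step a 3.0-fold lower number from compound 1 to compound 3 (0.48 log units; beyond the scatter) in this assay, beyond the usual scatter. Compound 3 is estimated at 0.7 ug/mL, within a range of 0.2 ug/mL to 2.5 ug/mL, with a real chance that only a limit is reported.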

Compound 3, solubility: < 1 ug/mL
Compound 3 was reported as a limit; the forecaster's own chance of this, stated with the estimate: 55%; the middle value lies beyond the limit too.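

In this assay, 2,4-difluorophenyl in place of methoxy on this aromatic carbon, para to a hydroxy group, gives the first step read at this position (an at least 2.1-fold lower number from compound 1 to compound 3 (0.32 log units; beyond the scatter)). Compound 3 gives < 1 ug/mL, which is a limit of the assay and not a number, so the step fixes only a minimum size for this change. With this result, the limit now holds most of the readings shown: the limit of < 1 ug/mL in this assay, at which 2 of the 3 values shown sit.

On these data alone, how far compound 3 lies past that limit stays open, as does whether the step belongs to the new ring or to its two fluorines, which a plain phenyl group could separate. Also open, as far as these compounds go, is whether an amine or a carboxylic acid on this aromatic carbon would give a number clear of the limit.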